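The source may report more compounds than this note shows. Statements on the series, on what has been measured and on what is new or still open speak of the compounds shown alone.

Measured in a functional assay on MCF7 cells (Homo sapiens) for antiproliferative activity, read by MTT assay, with a stated time of 72 h; a lower number here means a stronger inhibitor, a higher number a weaker inhibitor:
- Compound 1 `C/C=C/C(=O)Nc1cccc(Oc2nc(Nc3cccc(C#N)c3)nc3c2CSCC3)c1`: 21400 nM
- Compound 2 `CC/C=C/C(=O)Nc1cccc(Oc2nc(Nc3cccc(C#N)c3)nc3c2CSCC3)c1`: 15900 nM

Compound 2 has only compound 1 to stand against, and the two lie within the scatter of each other. Compound 3 `CC(C)/C=C/C(=O)Nc1cccc(Oc2nc(Nc3cccc(C#N)c3)nc3c2CSCC3)c1` follows from compound 2 by methyl in place of hydrogen on a saturated chain carbon bound to a double-bonded chain carbon and a saturated chain carbon. Among the measured compounds shown here, the one measured step that bears on this, likewise methyl in place of hydrogen on a saturated chain carbon bound to a double-bonded chain carbon, is a 1.3-fold lower number from compound 1 to compound 2 (0.13 log units; within the scatter). No change beyond the scatter is therefore expected in this assay. The expected step is a 1.1-fold lower number from compound 2 to compound 3 (0.06 log units; within the scatter). The estimate for compound 3 is 14000 nM, with an expected range of 7000 nM to 28000 nM.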

Compound 3, half-maximal inhibitory concentration: 29600 nM
The estimate for compound 3 lay 2.1-fold (0.33 log units) below the measured number, and the stated range ends below it.
By their numbers in this assay, from the lowest: compounds 2, 1 and 3 (each within the scatter of the next).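

In this assay the step is a 1.9-fold higher number from compound 2 to compound 3 (0.27 log units; within the scatter) when isopropyl takes the place of ethyl, and a 1.4-fold higher number from compound 1 to compound 3 (0.14 log units; within the scatter) when isopropyl takes the place of methyl. A second methyl in place of hydrogen on this chain thus leaves the number within the scatter, as the first did, and methyl, ethyl and isopropyl are not told apart here. Nothing available explains this result. The compounds shown leave open whether a tert-butyl, a phenyl or a dimethylamino group at this chain end would give a number beyond the scatter.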